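The compounds below may be only part of what the source reports. "The series", "measured", "known", "first", "only" and "open" are said of these compounds alone.

In a functional assay on Jurkat cells (Homo sapiens) for inhibition, read by MTT assay, with a stated time of 72 h (on this read-out lower numbers stand for stronger inhibition of growth and higher numbers for weaker inhibition of growth), compound 3 `CN(C)/C=N/c1cc(-c2ccc(Cl)cc2)nn1-c1cccc(Cl)c1` gives 74500 nM, the highest of the two numbers shown, and the nearest, compound 1 `CN(C)/C=N/c1c(C=O)c(-c2ccc(Cl)cc2)nn1-c1ccc(Br)cc1`, gives 38900 nM, a value within the usual scatter of it. Compound 2 `Cc1ccc(-c2cc(/N=C/N(C)C)n(-c3cccc(Cl)c3)n2)cc1` gives only > 100000 nM, which is a limit of the assay and not a number (the limit of > 100000 nM in this assay, at which 1 of the 3 values shown sits). Among the measured compounds shown here, the one step measured here is an at least 1.3-fold lower number from compound 2 to compound 3 (0.12 log units; that floor lies within the scatter), and its floor lies within the scatter. Compound 4 `CN(C)/C=N/c1cc(-c2ccc(Cl)cc2)nn1-c1ccc(Br)cc1` has not been measured; it differs from compound 3 in one place: 4-bromophenyl in place of 3-chlorophenyl on an aromatic nitrogen. For the measured compounds named here, no measured step changes the group on this aromatic nitrogen, so the size of the coming step can only be read off what two numbers show: compound 1, which also carries a 4-bromophenyl group on an aromatic nitrogen, and compound 3 lie within the scatter of each other. A step of about a 1.5-fold lower number from compound 3 to compound 4 (0.17 log units; within the scatter) is therefore expected, no larger than the scatter. Compound 4 is estimated at 50000 nM, between 20000 nM and 150000 nM.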

Compound 4, concentration for 50% growth inhibition: 84900 nM
Compound 4: the middle estimate sits 1.7-fold (0.23 log units) below what was measured; measured number inside the range.
By their numbers in this assay, from the lowest: compounds 1, 3 and 4 (each within the scatter of the next, the first and the last beyond it). At a limit, above all of these: compound 2.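

Putting 4-bromophenyl in place of 3-chlorophenyl on the aromatic nitrogen gives a 1.1-fold higher number from compound 3 to compound 4 (0.06 log units; within the scatter) in this assay, so these two groups cannot be told apart at this position on this core. The formyl group on the aromatic carbon tells a different story: hydrogen in its place gives a 2.2-fold higher number from compound 1 to compound 4 (0.34 log units; beyond the scatter), a modest step, yet the only one here that clearly clears the scatter. Nothing at hand explains either step.

On the aromatic nitrogen the compounds shown carry only phenyl rings with a halogen, so what an amine on that ring or a plain alkyl chain in place of the ring would do remains open. On the aromatic carbon only formyl and hydrogen appear, which leaves open how a carboxylic acid or a nitrile there would compare.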